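This account rests on a few compounds, and the source may have more. Where it says the series, first, only, none or still open, it means among the compounds named here.

Of the compounds shown here, two built on one shared core have been tested in a functional assay on MIA PaCa-2 cells (Homo sapiens) for inhibition, read by MTT assay, with a stated time of 3 days (a higher number here means a weaker inhibitor, a lower number a stronger inhibitor), and neither gave a number. Compound 1 `CC(C)S(=O)(=O)c1ccc(S(=O)(=O)N2CCC[C@@H](C(=O)N3CCC(F)(F)CC3)C2)cc1` sits at a limit of the assay, > 3000 nM, which is the limit of > 3000 nM in this assay, at which 1 of the 2 values shown sits. Compound 2 `CCN(CC)S(=O)(=O)c1ccc(S(=O)(=O)N2CCC[C@@H](C(=O)NC3CCOCC3)C2)cc1` likewise sits at a limit of the assay, > 10000 nM, which is the limit of > 10000 nM in this assay, at which 1 of the 2 values shown sits. Among the measured compounds shown here, compound 2 therefore stands beyond what this assay can report, and no measured step between compounds exists to show how a change at the amide substituent moves the result. Compound 3 `CCN(CC)S(=O)(=O)c1ccc(S(=O)(=O)N2CCC[C@@H](C(=O)N[C@@H]3CCOC3)C2)cc1` carries oxolan-3-yl in place of oxan-4-yl on an amide-type nitrogen. For the measured compounds named here, with no step to build on, the expected step is a step that the limit leaves unreadable from compound 2 to compound 3, that is, no change beyond the usual scatter, and compound 3 is expected to return only a limit again. Compound 3 is estimated at 15000 nM in this assay, within a range from 5000 nM to 50000 nM.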

Compound 3, half-maximal inhibitory concentration: > 10000 nM
Compound 3 gave a limit, no number (the forecaster's own chance of this, stated with the estimate: 85%); the middle value does not contradict the limit.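

In this assay compound 2 and compound 3 each give only a limit, not a number, so no step can be read for oxolan-3-yl in place of oxan-4-yl: the limit of > 10000 nM in this assay, at which 2 of the 3 values shown sit.

The compounds shown leave open whether any change on the amide-type nitrogen moves the result at all.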